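The compounds below may be only part of what the source reports. "The series", "measured", "known", "first", "only" and "open" are said of these compounds alone.

Measured so far in an ADME assay on microsomes from liver (Rattus norvegicus) for metabolic stability; a lower number here means that the compound disappears faster, a higher number that the compound lasts longer:
- compound 1 `CC(C)C(/C=C1\NC(=O)NC1=O)c1ccc(-c2ccc3cccc(F)c3c2)[nH]c1=O`: 1.46 h
- compound 2 `CCC(CC)C(/C=C1\OC(=O)NC1=O)c1ccc(-c2ccc3cccc(F)c3c2)[nH]c1=O`: > 3 h (a limit)
- compound 3 `O=C1NC(=O)/C(=C/C(c2ccc(-c3ccc4cccc(F)c4c3)[nH]c2=O)C2CC2)O1`: > 3 h (a limit)

Compound 3 stands at > 3 h, which is a limit and not a number.

Next comes compound 4 `O=C1NC(=O)/C(=C/C(Cc2ccccc2)c2ccc(-c3ccc4cccc(F)c4c3)[nH]c2=O)O1`. The change is benzyl in place of cyclopropyl on a saturated chain carbon bound to an aromatic carbon and a double-bonded chain carbon: benzyl in place of cyclopropyl, which brings in a six-membered aromatic ring of carbon only.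

Within the data shown here, the one measured step at this place is a step that the two limits leave unreadable from compound 2 to compound 3, so it offers no size to carry over. Neither end of that step is a number, and the record here is the limit of > 3 h in this assay, at which 2 of the 3 values shown sit.

Among the measured compounds shown here, the only true number belongs to compound 1, at 1.46 h, and that compound differs from compound 3 in more than one place. It shows only that a close relative can fall short of the limit, so a modest fall is expected, held loosely.

The expected move is an at least 1.2-fold lower number from compound 3 to compound 4 (0.07 log units; that floor lies within the scatter), a rough estimate. For compound 4 the estimated half-life is 2.5 h, with an expected range of 1 h to 5 h.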

Compound 4, half-life: 2.96 h
The estimate for compound 4 lay 1.2-fold (0.07 log units) below the measured number, within the range that was stated.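

In this assay, among these compounds, compound 4 gives 2.96 h, the first true number at this position among the compounds that share the core of compound 3. Benzyl in place of cyclopropyl gives an at least 1.0-fold lower number from compound 3 to compound 4 (0.00 log units; that floor lies within the scatter), and benzyl in place of pentan-3-yl gives an at least 1.0-fold lower number from compound 2 to compound 4 (0.00 log units; that floor lies within the scatter). So a six-membered aromatic ring of carbon only can be carried at this place with a half-life still measured close to the limit, yet the true size of both steps stays unknown, because the values of compound 2 and compound 3 are limits and not numbers: the limit of > 3 h in this assay, at which 2 of the 4 values shown sit.

As far as these compounds go, whether an amine or a carboxylic acid at this place would keep the half-life in the same range remains open. From the compounds shown here alone, it is also open whether benzyl would behave the same way on the core of compound 1.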